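This account rests on a few compounds, and the source may have more. Where it says the series, first, only, none or still open, it means among the compounds named here.

Going by the values given here, compound 2 `CCn1c(CNc2ccccc2)nnc1SCc1nc2cc(C(=O)C(C)C)ccc2o1` is the one compound in this set with a proper number: in an assay on isolated protein for inhibition of long-chain fatty acid transport protein 1 (Mus musculus) (a lower number here means a stronger inhibitor, a higher number a weaker inhibitor), compound 2 gives 520 nM. Compound 1 `CCn1c(CNc2ccccc2)nnc1SCC(=O)Nc1ccccc1` reaches only a limit, giving > 10000 nM in this assay. Compound 3 `CCn1nnc(-c2ccc(NC(=O)CSc3nnc(CNc4ccccc4)n3CC)cc2)n1` likewise stops at a limit, giving > 10000 nM in this assay. Among the compounds with values here, the single step among measured compounds, a step that the two limits leave unreadable from compound 1 to compound 3, stays unreadable because both of its ends sit at the limit of > 10000 nM in this assay, at which 2 of the 3 values shown sit. Compound 4 `CCC(O)c1ccc2oc(CSc3nnc(CNc4ccccc4)n3CC)nc2c1` carries 1-hydroxypropyl in place of isopropylcarbonyl on an aromatic carbon. Within the data shown here, no measured step touches this part of the molecule, so nothing among the three compounds fixes the size or direction of the change; only compound 2 itself, with 520 nM, anchors the estimate. The step is expected to be small, a 1.9-fold higher number from compound 2 to compound 4 (0.28 log units; within the scatter) in this assay. Compound 4 is estimated at 1000 nM, in a range from 300 nM to 4000 nM.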

Compound 4, half-maximal inhibitory concentration: 3700 nM
The estimate for compound 4 lay 3.7-fold (0.57 log units) below the measured number; measured number inside the range.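

Going by these compounds alone, putting 1-hydroxypropyl in place of isopropylcarbonyl on this aromatic carbon gives a 7.1-fold higher number from compound 2 to compound 4 (0.85 log units; beyond the scatter) in this assay, the only step in the set that can be read. The position therefore responds to change, and this change weakens inhibition, though compound 4 still gives a proper number. Nothing shown accounts for the size of this step. From the compounds shown here alone, it remains open whether the loss of the carbonyl or the entry of the hydroxyl matters more. Going by these compounds, how an amine, a carboxylic acid or a longer chain would fare at this position also remains open.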